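A few compounds are considered here, and "the series" means these few. Any claim that something is new, unique, unknown or untested is made for them only; others in the source may bear on it.

Working notes on the series. Compound 1 `COc1ncnc2c1c(-c1ccoc1)cn2[C@@H]1O[C@H](CO)[C@@H](O)[C@H]1O` carries a methoxy on the core and a furan-3-yl; in a functional assay on HCT-116 cells (Homo sapiens), read by MTT assay, with a stated time of 72 h (on this read-out lower numbers stand for stronger inhibition and higher numbers for weaker inhibition), compound 1 gives 130 nM. Compound 2 `CN(C)c1ncnc2c1c(-c1ccoc1)cn2[C@@H]1O[C@H](CO)[C@@H](O)[C@H]1O` differs only in bearing dimethylamino at that place; in this assay compound 2 returns only a limit, > 20000 nM. The change from compound 2 to compound 1 is methoxy in place of dimethylamino on an aromatic carbon and gives an at least 150-fold lower number from compound 2 to compound 1 (2.18 log units; beyond the scatter). Compound 3 `CN(C)c1ncnc2c1c(-c1cc3ccccc3o1)cn2[C@@H]1O[C@H](CO)[C@@H](O)[C@H]1O` keeps the dimethylamino of compound 2 and differs from it by 1-benzofuran-2-yl in place of furan-3-yl on an aromatic carbon; in this assay compound 3 also returns only a limit, > 20000 nM. The step from compound 2 to compound 3 is therefore a step that the two limits leave unreadable from compound 2 to compound 3, since both sit at the limit of > 20000 nM in this assay, at which 2 of the 3 values shown sit.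

Compound 4 `COc1ncnc2c1c(-c1cc3ccccc3o1)cn2[C@@H]1O[C@H](CO)[C@@H](O)[C@H]1O` has not been measured. It differs from compound 3 by methoxy in place of dimethylamino on an aromatic carbon, the same kind of change as from compound 2 to compound 1, made on the core that carries the 1-benzofuran-2-yl rather than the furan-3-yl. Whether the benzofuran itself costs or adds potency cannot be read from compound 2 and compound 3. A step of an at least 25-fold lower number from compound 3 to compound 4 (1.39 log units; beyond the scatter) in this assay is expected for compound 4, resting on the large step seen from compound 2 to compound 1 an at least 150-fold lower number from compound 2 to compound 1 (2.18 log units; beyond the scatter), tempered by the unreadable effect of the larger aryl. The estimate for compound 4 in this assay is 800 nM, between 100 nM and 15000 nM.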

Compound 4, half-maximal inhibitory concentration: 14500 nM
For compound 4 the middle estimate is 18-fold (1.26 log units) below the measured one; the range from low to high includes it.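

On the core carrying the 1-benzofuran-2-yl, methoxy in place of dimethylamino in this assay gives an at least 1.3-fold lower number from compound 3 to compound 4 (0.13 log units; that floor lies within the scatter), and the comparison with the core carrying the furan-3-yl reads: the same change on two cores in this assay, an at least 150-fold lower number (2.18 log units; beyond the scatter) from compound 2 to compound 1 and an at least 1.3-fold lower number (0.13 log units; that floor lies within the scatter) from compound 3 to compound 4; the limit leaves it open whether they differ. Compound 3 gives only a limit, > 20000 nM, so the data neither show that the large step seen with the furan-3-yl carries over at full size nor show that it is lost. With methoxy held fixed, 1-benzofuran-2-yl in place of furan-3-yl gives a 110-fold higher number from compound 1 to compound 4 (2.05 log units; beyond the scatter), so methoxy does not bring these two compounds to one level, and this pair alone does not show how the change would behave with any other aryl group.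

Going by these compounds, the step between the two dimethylamino compounds cannot be read, so the effect of the aryl swap with dimethylamino in place stays open. Also open, on these data alone, is how a group such as a primary amine or an ethoxy at the same place, or a thiophene as the aryl group, would behave on these cores.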